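The source may hold more compounds than are shown below. What is called first, only, known or untested is meant among the compounds shown, and "the series" means these compounds.

Working notes on the series. The shared core carries a variable group on an aromatic carbon between two ring nitrogen atoms. Going by the values given here, in a functional assay on MDA-MB-231 cells (Homo sapiens) for inhibition, read by sulforhodamine B assay, with a stated time of 48 h (on this read-out higher numbers stand for weaker inhibition of growth and lower numbers for stronger inhibition of growth), compound 1 `COc1ccc2c(c1)NC(=O)CN2c1nc(OCC2CC2)nc2ccccc12` gives 45.2 nM, the second highest of the three numbers so far. Compound 2 `COc1ccc2c(c1)NC(=O)CN2c1nc(Nc2cccc(C#N)c2)nc2ccccc12` gives 97.1 nM, and compound 3 `COc1ccc2c(c1)NC(=O)CN2c1nc(NC2CC2)nc2ccccc12` gives 10.5 nM.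

The next analogue is compound 4 `COc1ccc2c(c1)NC(=O)CN2c1nc(NC2CCCC2)nc2ccccc12`, with cyclopentylamino in place of cyclopropylmethoxy on an aromatic carbon. Among the compounds with values here, the closest precedent is a 4.3-fold lower number from compound 1 to compound 3 (0.63 log units; beyond the scatter), where cyclopropylamino enters at the same place. Against this stands a 2.1-fold higher number from compound 1 to compound 2 (0.33 log units; beyond the scatter), where (3-cyanophenyl)amino enters and the number rises. The group on the nitrogen therefore matters, as a 9.2-fold lower number from compound 2 to compound 3 (0.97 log units; beyond the scatter) also shows. No five-membered ring has been measured here, so the size of the step is uncertain.

Within the data shown here, a lower number in this assay is expected, though a smaller drop than the one to compound 3. The expected change is a 2.3-fold lower number from compound 1 to compound 4 (0.35 log units; beyond the scatter). For compound 4 the estimate is 20 nM, with an expected range of 7 nM to 60 nM.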

Compound 4, concentration for 50% growth inhibition: 17.6 nM
Beside the measured number, compound 4's estimate is 1.1-fold (0.06 log units) above it; the range from low to high includes it.
By their numbers in this assay, from the lowest: compounds 3 and 4 (each within the scatter of the next); then compound 1; then compound 2.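

In this assay there is a 2.6-fold lower number from compound 1 to compound 4 (0.41 log units; beyond the scatter), so the drop seen with cyclopropylamino at this aromatic carbon is not confined to that one group, although the (3-cyanophenyl)amino of compound 2 goes against it. Enlarging the ring on the nitrogen from three-membered to five-membered gives a 1.7-fold higher number from compound 3 to compound 4 (0.22 log units; within the scatter), so this change does not separate the two compounds. There is also a 5.5-fold lower number from compound 2 to compound 4 (0.74 log units; beyond the scatter), which shows that a second non-aromatic carbon ring on that nitrogen stands clear of 3-cyanophenyl, but no measurement is available to explain any of these steps.

As far as these compounds go, whether cyclohexylamino or an open-chain isopropylamino would read like these two cyclic amines remains open. Also open, from the compounds shown here alone, is how a longer chain on the nitrogen, ending in an amine or a carboxylic acid, would read.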